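This account rests on a few compounds, and the source may have more. Where it says the series, first, only, none or still open, it means among the compounds named here.

Of the compounds shown here, three built on the same core have been measured in a functional assay on HeLa cells (Homo sapiens) for cytotoxicity, read by sulforhodamine B assay, with a stated time of 48 h; on this read-out lower numbers stand for stronger inhibition and higher numbers for weaker inhibition. Compound 1 `CC(=O)OC[C@H]1O[C@@H](n2cc(CN3C(=O)/C(=C\C=C\c4ccccc4)c4ccccc43)nn2)[C@H](OC(C)=O)[C@@H](OC(C)=O)[C@@H]1OC(C)=O` gives 98100 nM. Compound 2 `CC(=O)OC[C@H]1O[C@@H](n2cc(CN3C(=O)/C(=C\c4ccc(N(C)C)cc4)c4ccccc43)nn2)[C@H](OC(C)=O)[C@@H](OC(C)=O)[C@@H]1OC(C)=O` gives 25000 nM, and compound 3 `CC(=O)OC[C@H]1O[C@@H](n2cc(CN3C(=O)/C(=C/c4ccc(N(C)C)cc4)c4ccccc43)nn2)[C@H](OC(C)=O)[C@@H](OC(C)=O)[C@@H]1OC(C)=O` gives 26300 nM. Among these three numbers compound 2 holds the lowest, with compound 3 close beside it and compound 1 further away. Among the compounds with values here, the step of a 3.9-fold lower number from compound 1 to compound 2 (0.59 log units; beyond the scatter) is the only exchange of the group on the double-bonded chain carbon seen so far. The step of a 1.1-fold higher number from compound 2 to compound 3 (0.02 log units; within the scatter) concerns the drawn geometry alone, and the fact that compounds 2 and 3 differ only in the configuration as drawn fits that no change beyond the scatter appears there.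

Compound 4 `CC(=O)OC[C@H]1O[C@@H](n2cc(CN3C(=O)/C(=C\c4ccco4)c4ccccc43)nn2)[C@H](OC(C)=O)[C@@H](OC(C)=O)[C@@H]1OC(C)=O` differs from compound 2 by furan-2-yl in place of 4-(dimethylamino)phenyl on a double-bonded chain carbon bound to a double-bonded ring carbon. Within the data shown here, no measured step puts a five-membered ring at this place, so the expectation rests on the single exchange from compound 1 to compound 2, which was modest in size. Compound 4 is therefore expected to land near 45000 nM, within a range from 15000 nM to 140000 nM. The expected step of a 1.8-fold higher number from compound 2 to compound 4 (0.26 log units; within the scatter) is a modest rise in the number, with its size uncertain.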

Compound 4, half-maximal inhibitory concentration: > 100000 nM
Compound 4 gave a limit, no number; the forecaster's own chance of this, stated with the estimate: 10%; middle value at least 2.2-fold (0.34 log units) from the limit.
By their numbers in this assay, from the lowest: compounds 2 and 3 (each within the scatter of the next); then compound 1. At a limit, above all of these: compound 4.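

In this assay, the group on a double-bonded chain carbon bound to a double-bonded ring carbon can also push the number up, as furan-2-yl in place of 4-(dimethylamino)phenyl gives an at least 4.0-fold higher number from compound 2 to compound 4 (0.60 log units; beyond the scatter). Against the 2-phenylethenyl group, the furan-2-yl exchange gives an at least 1.0-fold higher number from compound 1 to compound 4 (0.00 log units; that floor lies within the scatter), so this step does not separate those two groups. For compound 4 the read-out is a limit and not a number, so the full size of both steps stays unknown because of this: the limit of > 100000 nM in this assay, at which 1 of the 4 values shown sits.

Going by these compounds, whether a plain phenyl or a thiophen-2-yl at this place would stay close to compound 2 or rise towards compound 4 remains open. Also open, on these data alone, is whether the drawn geometry of the double bond matters with furan-2-yl, as only the 4-(dimethylamino)phenyl pair tests it.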